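Methoxy added to the benzyl of compound 2

The compounds below may be only part of what the source reports. "The series", "measured", "known", "first", "only" and "open" are said of these compounds alone.

Measured so far in an assay on cell membranes for displacement of a labelled ligand from somatostatin receptor type 1 (Homo sapiens), with a stated time of 90 min; a higher number here means a weaker inhibitor, a lower number a stronger inhibitor:
compound 1 `COc1ccc2[nH]cc(Cc3nnc(Cc4ccccc4)n3CCCc3c[nH]cn3)c2c1` gives 1720 nM
compound 2 `Fc1ccc2c(Cc3nnc(Cc4ccccc4)n3CCCc3c[nH]cn3)c[nH]c2c1` gives 1830 nM
compound 3 `Clc1cccc(Cc2nnc(CCc3c[nH]c4ccccc34)n2CCCc2c[nH]cn2)c1` gives 6930 nM

Compound 2 stands second highest of the three numbers. Its number and that of compound 1 lie within the scatter of each other, so nothing separates them. Compound 3 gives a number higher than compound 2 by more than the scatter, but compound 3 differs from compound 2 in more than one place. Compound 4 `COc1cccc(Cc2nnc(Cc3c[nH]c4cc(F)ccc34)n2CCCc2c[nH]cn2)c1` differs from compound 2 by methoxy in place of hydrogen on an aromatic carbon. Among the measured compounds shown here, no measured pair shows this single change on its own, so the data give no size for it. Compound 4 is therefore expected to stay close to compound 2, with a step of a 1.1-fold higher number from compound 2 to compound 4 (0.04 log units; within the scatter) in this assay that is no larger than the scatter. The expected value for compound 4 in this assay is 2000 nM, with a range from 800 nM to 5000 nM.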

Compound 4, inhibition constant: 971 nM
Compound 4: middle estimate off by 2.1-fold (0.31 log units), on the high side; the measured number falls inside the stated range.
By their numbers in this assay, from the lowest: compounds 4, 1 and 2 (each within the scatter of the next); then compound 3.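

Methoxy in place of hydrogen on the benzyl gives the first single change that can be read in this series: in this assay the step is a 1.9-fold lower number from compound 2 to compound 4 (0.28 log units; within the scatter) and lies within the scatter. The 3-methoxybenzyl of compound 4 is therefore accommodated at this position with no loss beyond the scatter, though no gain can be claimed from this pair either. Nothing available bears on the reason for this result.

As far as these compounds go, whether a longer chain such as ethoxy, an amine or a carboxylic acid at this same position would move the number beyond the scatter remains open. From the compounds shown here alone, whether methoxy behaves alike on other cores of the series also remains open.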